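The compounds below may be only part of what the source reports. "The series", "measured", "known", "first", "only" and "open" are said of these compounds alone.

Measured in a functional assay on Malme-3M cells (Homo sapiens) for inhibition, read by sulforhodamine B assay, with a stated time of 48 h, tested at 10 uM; a lower number here means less inhibition of growth, a higher number more inhibition of growth at the concentration tested:
- compound 1 `COc1ccc(-c2nc3sc(-c4ccccc4)cn3n2)cc1`: 32%
- compound 2 `COc1cc(-c2nc(N)n(CC(=O)Nc3ccc(/C(C)=N\O)cc3)n2)cc(OC)c1OC`: 3.25%
- compound 3 `Clc1ccc(-c2cn3nc(-c4ccccc4)nc3s2)cc1`: 10%

Compound 3 at 10% cannot be told apart from compound 2, while compound 1 lies higher, beyond the scatter. Compound 4 `COc1ccc(-c2nc3sc(-c4ccc(Cl)cc4)cn3n2)cc1` differs from compound 3 by methoxy in place of hydrogen on an aromatic carbon, para to a large group: methoxy in place of hydrogen on an aromatic carbon. Going by the values given here, no measured pair isolates this change. Compound 1 carries a methoxy group and gives 32%, which points to a small rise, yet compound 2 also carries methoxy groups and gives 3.25%. The expected step of a number 10 percentage points higher from compound 3 to compound 4 (within the scatter) is therefore a modest rise in this assay, near the edge of the scatter. Compound 4 is estimated at 20%, with an expected range of 6% to 38%.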

Compound 4, percent growth inhibition at one concentration: 49.2%
Compound 4: middle estimate off by 29.2 percentage points, on the low side; measured number outside the range, above it.
By their numbers in this assay, from the lowest: compounds 2 and 3 (each within the scatter of the next); then compound 1; then compound 4.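

In this assay the change of methoxy in place of hydrogen on an aromatic carbon, para to a large group, now has a matched pair, and with chloro present it gives a number 39.2 percentage points higher from compound 3 to compound 4 (beyond the scatter) as a large step. Chloro in place of hydrogen on an aromatic carbon also matters with methoxy present, giving a number 17.2 percentage points higher from compound 1 to compound 4 (beyond the scatter) as a modest step.

As far as these compounds go, whether methoxy has this effect without chloro, and how an amine or a longer alkoxy chain would compare at this carbon, stays open. Nothing measured here explains either step.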